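The source may hold more compounds than are shown below. What is called first, only, known or untested is meant among the compounds shown, and "the series" means these compounds.

Measured compounds:
compound 1 `Cc1ccc2nc(Nc3ccnc(Nc4ccc(S(C)(=O)=O)cc4)n3)sc2c1`: 2300 nM
compound 2 `NS(=O)(=O)c1ccc(Nc2nccc(Nc3nc4ccc(F)cc4s3)n2)cc1`: 450 nM

Both were tested in a functional assay on HeLa cells (Homo sapiens) for antiproliferative activity, read by MTT assay, with a stated time of 48 h; on this read-out lower numbers stand for stronger inhibition and higher numbers for weaker inhibition. Of these two numbers compound 1 stands highest; compound 2 gives the lower number, and the gap lies beyond the scatter. Compound 3 `CS(=O)(=O)c1ccc(Nc2nccc(Nc3nc4ccc(Cl)cc4s3)n2)cc1` has not yet been measured. It differs from compound 1 in one place: chloro in place of methyl on an aromatic carbon. Among the measured compounds shown here, no measured pair isolates this change, and compound 2 differs from compound 1 in more than one place, so its value shows only that a different combination reaches a lower number. A modest move toward a lower number is expected for compound 3, a 1.9-fold lower number from compound 1 to compound 3 (0.28 log units; within the scatter), near the edge of the scatter. The estimate for compound 3 is 1200 nM, ranging from 400 nM to 3500 nM.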

Compound 3, half-maximal inhibitory concentration: 1400 nM
For compound 3 the middle estimate is 1.2-fold (0.07 log units) below the measured one, within the range that was stated.
By their numbers in this assay, from the lowest: compound 2; then compounds 3 and 1 (each within the scatter of the next).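

In this assay, chloro in place of methyl on this aromatic carbon gives a 1.6-fold lower number from compound 1 to compound 3 (0.22 log units; within the scatter). Among the compounds shown here, this is the first pair to isolate the change, and it shows that, on this read-out, the two groups cannot be told apart at this position. Nothing measured here offers an explanation for this result.

Still open, as far as these compounds go, is whether a different group at this position, such as an amine or a carboxylic acid, would give a step beyond the scatter. From the compounds shown here alone, whether the same swap behaves alike on a different core also remains open.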